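Notes on the step from compound 1 to compound 4

A few compounds are considered here, and "the series" means these few. Any claim that something is new, unique, unknown or untested is made for them only; others in the source may bear on it.

Measured in a functional assay (plasma) for inhibition, with Homo sapiens as the target; a lower number here means a stronger inhibitor, a higher number a weaker inhibitor:
compound 1 `O=C(O)CCC/C=C\C[C@H]1/C(=N/OCC2CCCCC2)CC[C@@H]1NS(=O)(=O)c1ccc(F)cc1` gives 1800 nM
compound 2 `O=C(O)CCC/C=C\C[C@@H]1[C@H](O)CC[C@H]1NS(=O)(=O)c1ccc(F)cc1` gives 6000 nM
compound 3 `C[C@@H]1CC/C(=N\OC(c2ccccc2)c2ccccc2)[C@H]1C/C=C\CCCC(=O)O` gives 800 nM

Compound 1 stands second highest of the three numbers in this assay; compound 3 lies nearest, with a lower number beyond the scatter, and compound 2 lies furthest, with a higher number beyond the scatter. Compound 4 `Cc1ccc(S(=O)(=O)N[C@H]2CC/C(=N\OCC3CCCCC3)[C@@H]2C/C=C\CCCC(=O)O)cc1` is not yet measured. It differs from compound 1 in one place: methyl in place of fluoro on an aromatic carbon. Among the compounds with values here, no step between two measured compounds isolates this change, so its direction cannot be read from the present numbers. A step in this assay of a 1.2-fold lower number from compound 1 to compound 4 (0.08 log units; within the scatter) is expected, small and not beyond the scatter. Compound 4 is expected to give 1500 nM, within a range of 600 nM to 4000 nM.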

Compound 4, half-maximal inhibitory concentration: 600 nM
Compound 4: middle estimate off by 2.5-fold (0.40 log units), on the high side, and the stated range covers the measured number.
By their numbers in this assay, from the lowest: compounds 4 and 3 (each within the scatter of the next); then compound 1; then compound 2.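

In this assay, the change from 4-fluorophenyl to 4-methylphenyl gives a 3.0-fold lower number from compound 1 to compound 4 (0.48 log units; beyond the scatter) and shows that this aromatic carbon, para to a large group, is sensitive to replacing one heavy atom with another, with no change in the count of hydrogen-bond donors, acceptors or net charge. Within the data shown here, no earlier pair isolated any change at this place. No available evidence accounts for the step.

Going by these compounds, whether a chloro, methoxy, trifluoromethyl or ethyl group here would match methyl remains open. So does whether the step holds with the other oxime ether of compound 3.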